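Ethyl on the pyrazinyl amide of compound 3

The compounds below may be only part of what the source reports. "The series", "measured", "known", "first", "only" and "open" are said of these compounds alone.

Measured in an ADME assay (liver) for metabolic stability, with Liver microsome (Homo sapiens) as the target, using microsomes; a higher number here means faster removal of the compound, a lower number slower removal:
- Compound 1 `Cc1cc2c(Oc3cnc(C(=O)N4CC(C)(O)C4)cn3)cc(C(=O)Nc3cnccn3)cc2o1`: < 8 mL/min/kg, a limit of the assay
- Compound 2 `Cc1cc2c(Oc3cnc(C(=O)N4CC5(COC5)C4)cn3)cc(C(=O)Nc3cnccn3)cc2o1`: 12.9 mL/min/kg
- Compound 3 `Cc1cc2c(Oc3cnc(C(=O)N(C)C)cn3)cc(C(=O)Nc3cnccn3)cc2o1`: 15 mL/min/kg

Compound 3 gives 15 mL/min/kg. Its nearest number is reached by a 1.2-fold higher number from compound 2 to compound 3 (0.07 log units; within the scatter), so those two do not separate. Going by the values given here, the only other measured step to it is an at least 1.8-fold higher number from compound 1 to compound 3 (0.27 log units; that floor lies within the scatter), and that rests on a limit.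

Compound 4 `CCc1cnc(NC(=O)c2cc(Oc3cnc(C(=O)N(C)C)cn3)c3cc(C)oc3c2)cn1` carries one change, ethyl in place of hydrogen on an aromatic carbon: pyrazin-2-yl becomes 5-ethylpyrazin-2-yl, para to a large group. Among the compounds with values here, all the measured steps, including an at least 1.6-fold higher number from compound 1 to compound 2 (0.20 log units; that floor lies within the scatter), exchange the group on a carbonyl carbon. None of them touches this aromatic carbon, so they give no direct size for the change. The estimate therefore starts from compound 3 at 15 mL/min/kg and allows a modest upward move in this assay, as a judgement and not a measured trend. The expected change is a 1.6-fold higher number from compound 3 to compound 4 (0.20 log units; within the scatter). Compound 4 is expected at about 24 mL/min/kg, with an estimated range from 13 mL/min/kg to 45 mL/min/kg.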

Compound 4, clearance: 12.2 mL/min/kg
Estimate against measurement, compound 4: 2.0-fold (0.29 log units) above; the measured number lies below the stated range.
By their numbers in this assay, from the lowest: compounds 4, 2 and 3 (each within the scatter of the next). At a limit, below all of these: compound 1.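

In this assay, going by these compounds alone, this is the first reading at this aromatic carbon, and a 1.2-fold lower number from compound 3 to compound 4 (0.09 log units; within the scatter): ethyl in place of hydrogen does not separate the two compounds. Every earlier step exchanged the group on a carbonyl carbon, whereas this one shows that pyrazin-2-yl can become 5-ethylpyrazin-2-yl without a move beyond the scatter, at least with the dimethylamino amide in place. Nothing measured here gives a reason for this result.

A single group at this position sets no trend, so the compounds shown leave open whether a longer chain, a methoxy group or an amine on the same carbon would read alike. Also open, from the compounds shown here alone, is whether ethyl would leave the number in place on compound 1, which gives < 8 mL/min/kg, a limit of the assay.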